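A few compounds are considered here, and "the series" means these few. Any claim that something is new, unique, unknown or untested is made for them only; others in the source may bear on it.

Compound 1 `O=C(/C=C/c1ccoc1)c1cc(O)c(O)c([N+](=O)[O-])c1`: 71400 nM
Compound 2 `O=C(/C=C/c1nccs1)c1cc(O)c(O)c([N+](=O)[O-])c1`: 59200 nM
Compound 3 `CC(=O)N1N=C(c2cc(O)c(O)c([N+](=O)[O-])c2)CC1c1ccco1`: 77400 nM

These three compounds share a core and were tested in an assay on isolated protein for inhibition of Amine oxidase [flavin-containing] B (Homo sapiens), read by fluorescence; a higher number here means a weaker inhibitor, a lower number a stronger inhibitor. Compound 1 gives the second highest of the three numbers; its neighbours are compound 3, close to it, and compound 2, with a 1.2-fold lower number from compound 1 to compound 2 (0.08 log units; within the scatter). Compound 4 `O=C(/C=C/c1cccc(O)c1)c1cc(O)c(O)c([N+](=O)[O-])c1` has not been measured. It differs from compound 1 in one place: 3-hydroxyphenyl in place of furan-3-yl on a double-bonded chain carbon bound to a double-bonded chain carbon. For the measured compounds named here, the only measured step of a comparable kind, the swap of the ring on that chain carbon from compound 1 to compound 2, stayed within the scatter. On that basis a step of similar size, not beyond the scatter, is expected for a 1.3-fold lower number from compound 1 to compound 4 (0.11 log units; within the scatter). Compound 4 is therefore estimated at 55000 nM, with a range from 18000 nM to 160000 nM.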

Compound 4, half-maximal inhibitory concentration: 55800 nM
Compound 4: the middle estimate sits 1.0-fold (0.01 log units) below what was measured, and the stated range covers the measured number.
By their numbers in this assay, from the lowest: compounds 4, 2, 1 and 3 (each within the scatter of the next).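

Swapping a five-membered ring for the larger 3-hydroxyphenyl ring, which brings a hydrogen-bond donor, gives a 1.3-fold lower number from compound 1 to compound 4 (0.11 log units; within the scatter) and a 1.1-fold lower number from compound 2 to compound 4 (0.03 log units; within the scatter) in this assay. So this chain carbon has now taken rings of both sizes, with and without that donor, and all of these compounds remain within the scatter of one another. No measured evidence bears on why the number holds. Still open, going by these compounds, is whether an amine or a carboxylic acid on this ring would move the number beyond the scatter.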